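A few compounds are considered here, and "the series" means these few. Any claim that something is new, unique, unknown or untested is made for them only; others in the source may bear on it.

Measured in an in vitro ADME assay on microsomes from liver (Homo sapiens) for metabolic stability; on this read-out higher numbers stand for fast clearance and lower numbers for slow clearance:
- compound 1 `CC(C)NC(=O)[C@H]1CC[C@@H](n2/c(=N/C(=O)c3ccc(C#N)c(F)c3)[nH]c3ccc(CN4CCC(C(C)(C)O)CC4)cc32)CC1` gives 132 mL.min-1.g-1
- compound 2 `CC(C)NC(=O)[C@H]1CC[C@@H](n2/c(=N/C(=O)c3ccc(F)cc3)[nH]c3ccc(CN4CCC[C@H]4C(C)(C)O)cc32)CC1` gives 569 mL.min-1.g-1
- compound 3 `CC(C)NC(=O)[C@H]1CC[C@@H](n2/c(=N/C(=O)c3ccc(F)cc3)[nH]c3ccc(CN4CCCCC4)cc32)CC1` gives 302 mL.min-1.g-1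

Compound 1 has the lowest of the three numbers, with compound 3 and compound 2 both higher, beyond the scatter. Compound 4 `CC(C)NC(=O)[C@H]1CC[C@@H](n2/c(=N/C(=O)c3ccc(F)c(Cl)c3)[nH]c3ccc(CN4CCC(C(C)(C)O)CC4)cc32)CC1` carries 3-chloro-4-fluorophenyl in place of 4-cyano-3-fluorophenyl on a carbonyl carbon. Within the data shown here, the only measured step (a 1.9-fold lower number from compound 2 to compound 3 (0.28 log units; within the scatter)) lies within the scatter and sits at another place, so no measured step covers this change. Compound 3 (302 mL.min-1.g-1) has no nitrile and gives a higher number, but it also differs from compound 1 elsewhere, so this is weak support. A moderate upward step is therefore expected (a 1.7-fold higher number from compound 1 to compound 4 (0.24 log units; within the scatter)). For compound 4 the estimate is 230 mL.min-1.g-1, with an expected range of 110 mL.min-1.g-1 to 470 mL.min-1.g-1.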

Compound 4, intrinsic clearance in microsomes: 83 mL.min-1.g-1
Beside the measured number, compound 4's estimate is 2.8-fold (0.44 log units) above it; the measured number lies below the stated range.
By their numbers in this assay, from the lowest: compounds 4 and 1 (each within the scatter of the next); then compounds 3 and 2 (each within the scatter of the next).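

In this assay, among these compounds, this is the first matched reading at the aryl group on a carbonyl carbon: a 1.6-fold lower number from compound 1 to compound 4 (0.20 log units; within the scatter) for 3-chloro-4-fluorophenyl in place of 4-cyano-3-fluorophenyl. This exchange, which removes the nitrile and brings in chlorine, therefore stays within the scatter on the shared remainder of the molecule. No measurement bears on the reason for this result.

Both substituents differ between the two aryl groups, so the step cannot be assigned to either one alone. On these data alone, whether a trifluoromethyl group in place of the chlorine would also stay within the scatter remains open.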